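A few compounds are considered here, and "the series" means these few. Any claim that something is new, unique, unknown or untested is made for them only; others in the source may bear on it.

Two compounds have been measured in a functional assay on HEK293 cells for antagonist activity at transient receptor potential cation channel subfamily V member 1 (Homo sapiens), read by calcium flux; a lower number here means a stronger inhibitor, a higher number a weaker inhibitor:
compound 1 `O=C(Nc1ccc(I)cc1)c1ccc(C(=O)C(F)(F)F)cc1`, 790 nM
compound 2 `O=C(Nc1ccc(I)cc1)c1ccc(OC(F)(F)F)cc1`, 280 nM

Going by the values given here, compound 2 holds the lower of the two numbers; the single measured step, a 2.8-fold lower number from compound 1 to compound 2 (0.45 log units; beyond the scatter), separates it from compound 1. Compound 3 `CS(=O)(=O)c1ccc(C(=O)Nc2ccc(I)cc2)cc1` differs from compound 2 by methylsulfonyl in place of trifluoromethoxy on an aromatic carbon. Among the compounds with values here, no measured step involves a methylsulfonyl group, so the only guide is that the one known exchange at this place gave a modest step. Compound 3 is therefore expected to give 600 nM, within 200 nM to 2000 nM, an estimated 2.1-fold higher number from compound 2 to compound 3 (0.33 log units; beyond the scatter) toward a weaker inhibitor.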

Compound 3, half-maximal inhibitory concentration: > 10000 nM
Compound 3: a limit, no number; the forecaster's own chance of this, stated with the estimate: 10%; at least 16-fold (1.22 log units) between middle value and limit.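

In this assay compound 3 gives a limit of the assay, not a number: the limit of > 10000 nM in this assay, at which 1 of the 3 values shown sits. Methylsulfonyl on this aromatic carbon, para to a large group, brings a far larger change than the one earlier exchange, with an at least 35-fold higher number from compound 2 to compound 3 (1.55 log units; beyond the scatter) and an at least 12-fold higher number from compound 1 to compound 3 (1.10 log units; beyond the scatter). The position is therefore not merely a place of modest steps, since one exchange here is enough to carry the reading to the limit.

The compounds shown leave open how far compound 3 lies past that limit. They also leave open whether a nitrile, an amine or a plain methyl at this place would still give a number.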